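The source may hold more compounds than are shown below. What is called first, only, known or untested is meant among the compounds shown, and "the series" means these compounds.

The compounds here were tested in an ADME assay on BHK cells (Mesocricetus auratus) for cytotoxicity, read by MTT assay, with a stated time of 96 h; on this read-out lower numbers stand for higher toxicity in this test and higher numbers for lower toxicity in this test. Compound 1 `O=C(CN1CCCCC1)Nc1ccc(-c2nc3cc(Cl)c(Cl)cc3[nH]2)cc1` carries two chlorine atoms on its core and an amide-linked side chain, and in this assay compound 1 gives 39000 nM. Compound 2 `O=C(CN1CCN(c2ccccc2)CC1)Nc1ccc(-c2nc3cc(C(F)(F)F)ccc3[nH]2)cc1` has a trifluoromethyl group on the core and a larger amide-linked side chain. In this assay compound 2 reaches only a limit of the test, > 100000 nM. Compound 3 `COc1cc(OC)cc(-c2nc3cc(C(F)(F)F)ccc3[nH]2)c1` also carries the trifluoromethyl group, but its six-membered aromatic ring bears two methoxy groups and no amide. In this assay compound 3 likewise gives only a limit of the test, > 100000 nM. So compound 3 stands at the limit of > 100000 nM in this assay, at which 2 of the 3 values shown sit; no number separates it from compound 2, and the value of compound 1 is the only one that falls under that limit.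

Compound 4 `COc1cccc(-c2nc3cc(C(F)(F)F)ccc3[nH]2)c1` differs from compound 3 in one place: hydrogen in place of methoxy on an aromatic carbon. Going by the values given here, no measured pair differs by just such a change, so nothing measured fixes the size of this step. The expected step in this assay is none beyond the scatter. The step of a number no higher from compound 3 to compound 4 (the limit leaves the size open) is therefore what is expected here. Compound 4 is estimated at 100000 nM, with a range from 50000 nM to 200000 nM, and most likely the test will again report only its limit.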

Compound 4, half-maximal cytotoxic concentration: 90000 nM
Estimate against measurement, compound 4: 1.1-fold (0.05 log units) above; low and high end bracket the measured number.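

Among the compounds with trifluoromethyl on the core, compound 4 alone gives a number, 90000 nM, rather than a limit, so one side of this change now has a firm value. In this assay, putting hydrogen in place of methoxy on this aromatic carbon gives an at least 1.1-fold lower number from compound 3 to compound 4 (0.04 log units; that floor lies within the scatter), and this figure is only a floor for the step. The real step may lie within the usual scatter or may be larger, and nothing fixes its upper end, because compound 3 sits at the top of the test and gives no number of its own: the limit of > 100000 nM in this assay, at which 2 of the 4 values shown sit.

As far as these compounds go, it remains open whether this methoxy group has any real bearing on the read-out, and whether the methoxy group that stays on compound 4 does. How an amine, a carboxylic acid or a longer chain such as ethoxy would read at this same place on the ring cannot be told from the compounds shown.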